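Pyrazole to Pyridine on the Thiazole Series: Expected Potency

The source may report more compounds than this note shows. Statements on the series, on what has been measured and on what is new or still open speak of the compounds shown alone.

Measured compounds:
compound 1 `N#Cc1cc(-c2nc(C(c3ccc(F)cc3)c3ccc(F)cc3)sc2CC(=O)O)ccc1F` — 520 nM
compound 2 `O=C(O)Cc1sc(C(c2ccc(F)cc2)c2ccc(F)cc2)nc1-c1cn[nH]c1` — 220 nM

Among the compounds with values here, in an in vitro functional assay on HEK285-7 cells for antagonist activity at prostaglandin D2 receptor 2 (Homo sapiens), read by BRET and beta-arrestin recruitment (on this read-out lower numbers stand for stronger inhibition and higher numbers for weaker inhibition), compound 2 gives the lower of the two numbers, and the only measured step, a 2.4-fold lower number from compound 1 to compound 2 (0.37 log units; beyond the scatter), separates it from compound 1. Compound 3 `O=C(O)Cc1sc(C(c2ccc(F)cc2)c2ccc(F)cc2)nc1-c1ccncc1` differs from compound 2 by pyridin-4-yl in place of 1H-pyrazol-4-yl on an aromatic carbon. Within the data shown here, no measured step tests this exact exchange; the step from compound 1 to compound 2 shows only that swapping the group at this position moves the number modestly. A small change toward a higher number is therefore expected, estimated as a 1.6-fold higher number from compound 2 to compound 3 (0.20 log units; within the scatter), giving compound 3 an expected 350 nM within 120 nM to 1000 nM.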

Compound 3, half-maximal inhibitory concentration: 40 nM
Beside the measured number, compound 3's estimate is 8.8-fold (0.94 log units) above it, and the stated range ends above it.
By their numbers in this assay, from the lowest: compound 3; then compound 2; then compound 1.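

In this assay, within the data shown here, this position responds strongly to the ring it carries: pyridin-4-yl in place of 1H-pyrazol-4-yl gives a 5.5-fold lower number from compound 2 to compound 3 (0.74 log units; beyond the scatter), and pyridin-4-yl in place of 3-cyano-4-fluorophenyl gives a 13-fold lower number from compound 1 to compound 3 (1.11 log units; beyond the scatter), the only step here printed as large. Compound 3 carries no hydrogen-bond donor on this ring, so a donor there is not required for the lowest number in this set. Nothing available explains the gain. The compounds shown leave open whether the ring nitrogen must stand as in pyridin-4-yl, since neither pyridin-3-yl nor plain phenyl appears among them.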